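A few compounds are considered here, and "the series" means these few. Any claim that something is new, unique, unknown or untested is made for them only; others in the source may bear on it.

Compound 1, `COc1ccc(-c2nc3cc(NC(=O)[C@H](C)Oc4cccc(F)c4F)ccc3o2)cc1`: in an assay on isolated protein for inhibition of GMP reductase 2 (Homo sapiens), read by spectrophotometry (a higher number here means a weaker inhibitor, a lower number a stronger inhibitor), compound 1 gives > 5000 nM, which is a limit of the assay.
Compound 2, `C[C@H](Oc1cccc(Cl)c1Cl)C(=O)Nc1ccc2oc(-c3ccc(OC(F)(F)F)cc3)nc2c1`: in this assay compound 2 gives > 5000 nM, also a limit of the assay.

Within the data shown here, compound 2 therefore has no measured number in this assay, only a limit, and the single other value shown for this assay is a limit as well. Among the measured compounds shown here, both results sit at the limit of > 5000 nM in this assay, at which 2 of the 2 values shown sit, so neither compound can be ordered against the other, and no step between measured compounds is available.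

Compound 3, `C[C@H](Oc1cccc(Cl)c1Cl)C(=O)Nc1ccc2oc(-c3ccc(O)cc3)nc2c1`, differs from compound 2 in one place: hydrogen in place of trifluoromethyl on an oxygen on an aromatic ring. For the measured compounds named here, with no measured step to lean on, the expectation for compound 3 rests only on the standing of compound 2 at the limit and on the small size of the change. The step that the limit leaves unreadable from compound 2 to compound 3 is expected to be modest, with no clear direction beyond the scatter of repeated measurements. Compound 3 is therefore estimated at 8000 nM in this assay, within a range from 1500 nM to 40000 nM, with a real chance that the assay again reports only a limit.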

Compound 3, inhibition constant: > 5000 nM
Compound 3: only a limit was reported (the forecaster's own chance of this, stated with the estimate: 65%); the middle value does not contradict the limit.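

In this assay compound 3 gives > 5000 nM, a limit of the assay and not a number. Compound 2 also has only a limit, so no step from it to compound 3 can be read: the limit of > 5000 nM in this assay, at which 3 of the 3 values shown sit.

The compounds shown leave open how strongly any of them inhibits the enzyme, and whether replacing trifluoromethoxy with hydroxy changes that at all.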